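The source may hold more compounds than are shown below. What is called first, only, known or untested is meant among the compounds shown, and "the series" means these compounds.

Measured compounds:

Compound 1 `CCN(CC)c1nc(C)nc2c1nnn2-c1ccc(C(C)C)cc1Br` gives 25.3 nM in an in vitro assay on 293-EBNA cells for binding affinity to corticotropin-releasing factor receptor 1 (Homo sapiens); a lower number here means a stronger inhibitor, a higher number a weaker inhibitor.
Compound 2 `CCN(c1nc(C)nc2c1nnn2-c1ccc(C(C)C)cc1Br)C(COC)COC` gives 123 nM in this assay.
Compound 3 `CCC(Nc1nc(C)nc2c1nnn2-c1ccc(C(C)C)cc1Br)C(=O)OC` gives 19.4 nM in this assay.

Compound 3 has the lowest number of the three, but its gap to compound 1 is within the scatter, so the two cannot be told apart; only compound 2 stands clearly apart, with a 6.3-fold lower number from compound 2 to compound 3 (0.80 log units; beyond the scatter). All three compounds share the same core and differ only in what hangs on the ring nitrogen. Compound 4 `CCCC(CN(C)C)Nc1nc(C)nc2c1nnn2-c1ccc(C(C)C)cc1Br` continues this: a group of 8 heavy atoms (7 carbon, 1 nitrogen; no ring) in place of a group of 7 heavy atoms (5 carbon, 2 oxygen; no ring), on a nitrogen on an aromatic ring. The steps seen so far on this position are mixed: a 4.9-fold higher number from compound 1 to compound 2 (0.69 log units; beyond the scatter), a 1.3-fold lower number from compound 1 to compound 3 (0.12 log units; within the scatter) and a 6.3-fold lower number from compound 2 to compound 3 (0.80 log units; beyond the scatter). Two of these three changes stayed within or near the scatter, and the one clear loss came with compound 2, whose entering group carried two methoxy arms. Compound 4 keeps a hydrogen on the ring nitrogen as compound 3 does, which gives no reason to expect a large shift. For compound 4 a step of a 1.8-fold higher number from compound 3 to compound 4 (0.26 log units; within the scatter) is therefore expected, leaving compound 4 at an estimated 35 nM, with a range from 10 nM to 120 nM.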

Compound 4, inhibition constant: 38.7 nM
The estimate for compound 4 lay 1.1-fold (0.04 log units) below the measured number; low and high end bracket the measured number.
By their numbers in this assay, from the lowest: compounds 3, 1 and 4 (each within the scatter of the next); then compound 2.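

In this assay, replacing 1-(methoxycarbonyl)propyl with a group of 8 heavy atoms (7 carbon, 1 nitrogen) gives a 2.0-fold higher number from compound 3 to compound 4 (0.30 log units; within the scatter) and so stays within the scatter, even though the entering group has no oxygen and no double bond outside the aromatic rings. The same holds against the diethylamino compound, with a 1.5-fold higher number from compound 1 to compound 4 (0.18 log units; within the scatter) as the printed step, so the oxygens and carbonyl of compound 3 are not required to keep the number in this range. Compound 2 remains the one that stands apart, with a 3.2-fold lower number from compound 2 to compound 4 (0.50 log units; beyond the scatter) as a step beyond the scatter. No evidence is available that explains these results. The compounds shown leave open whether a carboxylic acid or a longer carbon chain on this nitrogen would keep the number in the same range.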